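Thiophen-2-yl Replaced by Phenyl: What Inhibition to Expect

The compounds below may be only part of what the source reports. "The series", "measured", "known", "first", "only" and "open" are said of these compounds alone.

Compound 1, `N=C(S)CCn1nc(-c2cccs2)ccc1=O`: 50.2%
Compound 2, `C/N=C(\S)C(C)Cn1ncccc1=O`: 50.2%

In a functional assay on the whole organism (stomach) for inhibition, with Rattus norvegicus as the target, at a dose of 100 mg/kg by the intraduodenal route (a lower number here means less inhibition, a higher number more inhibition at the dose given (going by the name of the read-out)), compound 1 gives 50.2%, level at the digits shown with compound 2, which in this assay gives 50.2%; the two lie within the scatter of each other, so neither stands above the other. Compound 3, `N=C(S)CCn1nc(-c2ccccc2)ccc1=O`, differs from compound 1 in one place: phenyl in place of thiophen-2-yl on an aromatic carbon. Among the measured compounds shown here, no step between measured compounds resembles this change, so no shift beyond the scatter is expected in this assay in either direction. Compound 3 is therefore estimated to give about 50% in this assay, within 35% to 65%. The expected step of a number 0.2 percentage points lower from compound 1 to compound 3 (within the scatter) is none beyond the scatter.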

Compound 3, a percentage reported as inhibition, in the whole organism at one dose (the size of the read-out at that dose, not a potency): 53.7%
The estimate for compound 3 lay 3.7 percentage points below the measured number; the measured number falls inside the stated range.
By their numbers in this assay, from the lowest: compounds 1, 2 and 3 (each within the scatter of the next).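

In this assay, phenyl in place of thiophen-2-yl on this aromatic carbon gives a number 3.5 percentage points higher from compound 1 to compound 3 (within the scatter), so this read-out at this dose does not separate the two rings at this position. The sulfur of thiophen-2-yl is therefore not needed to keep inhibition at this level, since the all-carbon six-membered ring serves as well here. Nothing at hand bears on why the two groups read alike.

The compounds shown leave open how an amine, a carboxylic acid or a longer chain would read on this carbon. They also leave open whether the two rings would still read alike at other doses.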